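The source may hold more compounds than are shown below. What is called first, only, known or untested is meant among the compounds shown, and "the series" means these compounds.

Compound 1 `Nc1ccccc1NC(=O)/C=C/c1ccc(CSc2ccc(F)cc2)cc1`: in a functional assay on SMMC-7721 cells (Homo sapiens) for inhibition, read by CCK-8 assay, with a stated time of 72 h, tested at 8 uM (on this read-out lower numbers stand for less inhibition of growth and higher numbers for more inhibition of growth at the one concentration tested), compound 1 gives 15.4%.
Compound 2 `Nc1ccccc1NC(=O)/C=C/c1ccc(CSc2cccc(F)c2)cc1`: in this assay compound 2 gives 8.25%.
Compound 3 `CC(C)(C)c1ccc(SCc2ccc(/C=C/C(=O)Nc3ccccc3N)cc2)cc1`: in this assay compound 3 gives 23.6%.

Compound 3 holds the highest of the three numbers. Its nearest neighbour is compound 1, with a number 8.2 percentage points higher from compound 1 to compound 3 (within the scatter), a step that stays within the scatter; the step of a number 15.4 percentage points higher from compound 2 to compound 3 (beyond the scatter) is the only one beyond the scatter. Between compound 1 and compound 2 the step of a number 7.2 percentage points lower from compound 1 to compound 2 (within the scatter) is within the scatter.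

Compound 4 `CCc1ccc(SCc2ccc(/C=C/C(=O)Nc3ccccc3N)cc2)cc1` differs from compound 3 in one place: ethyl in place of tert-butyl on an aromatic carbon. For the measured compounds named here, two measured steps bear on this change, both of them ending at compound 3 and both introducing the tert-butyl group that now leaves: a number 8.2 percentage points higher from compound 1 to compound 3 (within the scatter) and a number 15.4 percentage points higher from compound 2 to compound 3 (beyond the scatter). One is within the scatter and the other modest, so the group that leaves accounted for at most a modest gain. Going by the values given here, no measured pair shows an ethyl group, so the effect of the group that enters is unknown. The expectation for this assay is a small step downward that does not go beyond the scatter: a number 5.6 percentage points lower from compound 3 to compound 4 (within the scatter) is the estimated change. Compound 4 is expected to give 18%, with a range from 8% to 28%.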

Compound 4, percent growth inhibition at one concentration: 19.5%
Beside the measured number, compound 4's estimate is 1.5 percentage points below it; low and high end bracket the measured number.
By their numbers in this assay, from the lowest: compounds 2, 1, 4 and 3 (each within the scatter of the next, the first and the last beyond it).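

At the aromatic carbon para to a large group, ethyl in place of tert-butyl gives a number 4.1 percentage points lower from compound 3 to compound 4 (within the scatter) in this assay, so this position tolerates the exchange of one alkyl group for the other without a change that can be told from the scatter; the same holds for ethyl in place of fluoro, with a number 4.1 percentage points higher from compound 1 to compound 4 (within the scatter). For the compounds shown here, the one step from compound 4 that goes beyond the scatter is a number 11.3 percentage points higher from compound 2 to compound 4 (beyond the scatter), which adds a second compound bearing an alkyl group that stands clear of compound 2, as compound 3 does, although compound 1, with its 4-fluorophenyl group, goes against any simple alkyl-over-fluoro reading, since it does not stand clear of compound 2 and cannot be told from compound 4. No measurement at hand offers an explanation for any of these steps.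

The compounds shown leave open whether a longer chain such as hexyl, an amine or a carboxylic acid at this carbon would move the number beyond the scatter from compound 3. They also leave open how these compounds would compare at other concentrations, since each number comes from a single concentration in a single cell line.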